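The source may report more compounds than this note shows. Statements on the series, on what has been measured and on what is new or still open speak of the compounds shown alone.

Measured so far in a functional assay on HT-1080 cells (Homo sapiens) for antiproliferative activity, read by sulforhodamine B assay, with a stated time of 48 h; a lower number here means a stronger inhibitor, a higher number a weaker inhibitor:
compound 1, `CCCC(=O)Nc1cccc(S(=O)(=O)Oc2ccccc2C(C)C)c1`: 15000 nM
compound 2, `CCCCCC(=O)Nc1ccc(S(=O)(=O)Oc2ccccc2C(C)C)cc1`: 6300 nM
compound 3, `CCCCCC(=O)Nc1ccc(S(=O)(=O)Oc2ccccc2I)cc1`: 9600 nM

Compound 2 holds the lowest number of the three. Compound 3 sits nearest, a 1.5-fold higher number from compound 2 to compound 3 (0.18 log units; within the scatter), so the two cannot be ordered. Compound 1, at 15000 nM, is the furthest and lies beyond the scatter from compound 2.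

Compound 4, `CC(C)c1ccccc1OS(=O)(=O)c1ccc(NC(=O)NC2CCCC2)cc1`, differs from compound 2 by cyclopentylamino in place of pentyl on a carbonyl carbon. Within the data shown here, no measured step touches this part of the molecule: the single step, a 1.5-fold higher number from compound 2 to compound 3 (0.18 log units; within the scatter), concerns a substituent on the phenyl ester side, so nothing here informs the amide-to-urea exchange. With no guidance, no step beyond the scatter is expected in this assay. Compound 4 is therefore estimated at 8000 nM, range 3000 nM to 20000 nM, which would mean a 1.3-fold higher number from compound 2 to compound 4 (0.10 log units; within the scatter) as the expected step.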

Compound 4, half-maximal inhibitory concentration: 3900 nM
Estimate against measurement, compound 4: 2.1-fold (0.31 log units) above; the range from low to high includes it.
By their numbers in this assay, from the lowest: compounds 4, 2, 3 and 1 (each within the scatter of the next, the first and the last beyond it).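

In this assay, among these compounds, this is the first measured change on the carbonyl carbon whose other neighbour is the amide-type nitrogen, and cyclopentylamino in place of pentyl gives a 1.6-fold lower number from compound 2 to compound 4 (0.21 log units; within the scatter). Compound 2 and compound 4 therefore cannot be ordered, even though the entering group brings a five-membered ring and a hydrogen-bond donor. Nothing shown offers a measured reason for this result. Still open, going by these compounds, is whether a longer chain, a piperidine ring or a carboxylic acid on this carbonyl carbon would give a step beyond the scatter, and whether cyclopentylamino gives a similar result with the iodo group of compound 3.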